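Shortening the chain from compound 2 to compound 4

A few compounds are considered here, and "the series" means these few. Any claim that something is new, unique, unknown or untested is made for them only; others in the source may bear on it.

Measured in a functional assay on K562 cells (Homo sapiens) for cytotoxicity, read by MTT assay; a higher number here means that more compound is needed for the effect, a lower number that less compound is needed:
- compound 1 `CCCCCCCCCCCCCC[C@@H](O)[C@@H](O)[C@H](CO)n1cc(CCC)nn1`: 14900 nM
- compound 2 `CCCCCCCCCCCCC/C=C/[C@@H](O)[C@H](CO)n1cc(CCCCCCCCCCCCC)nn1`: > 50000 nM (a limit)
- compound 3 `CCCCCCCCCCCCC/C=C/[C@@H](O)[C@H](CO)n1cc(CCCCCCCCCCCCCCCCCCCCCCCC)nn1`: > 50000 nM (a limit)

Compound 2 sits at the limit of > 50000 nM in this assay, at which 2 of the 3 values shown sit. Its entry is a limit and not a number, so it offers no exact starting point.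

Compound 4 `CCCCCCCCCCCCC/C=C/[C@@H](O)[C@H](CO)n1cc(CCCC)nn1` is the next to be read. Going from compound 2 to compound 4, hydrogen comes in place of nonyl on a saturated chain carbon, four bonds along the chain from an aromatic carbon: hydrogen in place of nonyl on a saturated chain carbon, four bonds along the chain from an aromatic carbon.

Within the data shown here, the only measured step on this chain is a step that the two limits leave unreadable from compound 2 to compound 3. It gives no size to carry over, and it runs toward a longer chain, not a shorter one. Among the measured compounds shown here, the expectation therefore rests on compound 1 at 14900 nM, the only number and a weak anchor, since its structure also differs away from this chain. A move into the measurable range of this assay is expected, toward a lower number, though a second limit remains possible.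

The expected change is an at least 2.5-fold lower number from compound 2 to compound 4 (0.39 log units; beyond the scatter). For compound 4 the estimated value is 20000 nM, with an expected range of 7000 nM to 50000 nM.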

Compound 4, half-maximal effective concentration: 12300 nM
Beside the measured number, compound 4's estimate is 1.6-fold (0.21 log units) above it, within the range that was stated.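

In this assay, among these compounds, hydrogen in place of nonyl on a saturated chain carbon, four bonds along the chain from an aromatic carbon, gives an at least 4.0-fold lower number from compound 2 to compound 4 (0.60 log units; beyond the scatter), the first readable step on this chain. Compound 4 therefore brings this chain into the measurable range, at 12300 nM, whereas the step between the two longer-chain compounds cannot be read. The entry for compound 2 is a limit and so is the entry for compound 3, which leaves the size of the step open on one side: the limit of > 50000 nM in this assay, at which 2 of the 4 values shown sit.

The compounds shown do not locate the chain length at which the read-out leaves the limit, and a phenyl ring or a terminal amine in place of the chain remains untested within this set. As far as these compounds go, compound 1 differs from compound 4 in more than one place, so the contribution of its saturated backbone with the extra hydroxyl, separate from that of its chain, also stays open.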